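The compounds below may be only part of what the source reports. "The series", "measured", "known", "first", "only" and "open" are said of these compounds alone.

Compound 2 `Oc1ccc(-c2cc(-c3cccc(Cl)c3)nc(-c3cccs3)c2)cc1` is one of three analogues read in a functional assay on HCT-15 cells (Homo sapiens) for cytotoxicity, read by CCK-8 assay and cell counting, with a stated time of 2 days; on this read-out higher numbers stand for weaker inhibition and lower numbers for stronger inhibition. In this assay compound 2 gives 5050 nM, the second highest of the three numbers. Compound 1 `Oc1ccc(-c2cc(-c3ccc(Cl)cc3)nc(-c3cccs3)c2)cc1` gives 6470 nM in this assay, and compound 3 `Oc1cccc(-c2cc(-c3cccc(Cl)c3)nc(-c3cccs3)c2)c1` gives 2610 nM in this assay. The two single-point changes among these compounds are a 1.3-fold lower number from compound 1 to compound 2 (0.11 log units; within the scatter) and a 1.9-fold lower number from compound 2 to compound 3 (0.29 log units; within the scatter), both inside the usual scatter of this assay, so nothing in the measured set shows a step that can be told apart from repeat noise.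

Compound 4 `Oc1ccc(-c2cc(-c3cccc(Cl)c3)nc(-c3ccco3)c2)cc1` differs from compound 2 in one place: furan-2-yl in place of thiophen-2-yl on an aromatic carbon. Among the compounds with values here, none of the measured steps touches this group; the changes measured so far concern the position of the chloro group and of the hydroxy group on their phenyl rings, and both were flat. Within the data shown here, there is therefore no measured step that bears directly on the exchange of thiophen-2-yl for furan-2-yl, and by default the expectation is a step in this assay that stays within the scatter, with no clear direction. On that basis compound 4 is estimated to give 5000 nM in this assay, the expected step being a 1.0-fold lower number from compound 2 to compound 4 (0.00 log units; within the scatter), with a likely range from 2000 nM to 12500 nM.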

Compound 4, half-maximal inhibitory concentration: 8020 nM
Estimate against measurement, compound 4: 1.6-fold (0.21 log units) below, and the stated range covers the measured number.
By their numbers in this assay, from the lowest: compounds 3, 2, 1 and 4 (each within the scatter of the next, the first and the last beyond it).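

The exchange at this position, on the aromatic carbon next to the ring nitrogen, gives a 1.6-fold higher number from compound 2 to compound 4 (0.20 log units; within the scatter) in this assay and is the first change shown to reach this group rather than the placement of the chloro or hydroxy group on a phenyl ring. Within the data shown here, the two groups have the same heavy-atom count, and the oxygen of furan-2-yl stands where thiophen-2-yl carries sulfur, so this one-atom exchange in the five-membered aromatic ring gives no step that can be told apart from repeat noise. The compounds shown offer no measured property or other evidence that could explain the size or direction of this step.

From the compounds shown here alone, it remains open whether the same exchange would stay as flat with the 4-chlorophenyl group of compound 1 or the 3-hydroxyphenyl group of compound 3. Going by these compounds, it is also open whether this position would tolerate something quite different from these two five-membered aromatic rings, such as a plain phenyl ring, an amine or a carboxylic acid.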